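A few compounds are considered here, and "the series" means these few. Any claim that something is new, unique, unknown or untested is made for them only; others in the source may bear on it.

Working notes on the series. Compound 1 `CC(C)OC(=O)N1CCC(Oc2ncnc3c2CCN3c2ccc(S(C)(=O)=O)cc2F)CC1` gives 91% in a functional assay on CHO-K1 cells with Glucose-dependent insulinotropic receptor (Homo sapiens) as the target, read by a luciferase reporter, with a stated time of 5 h; a lower number here means a smaller maximal response, a higher number a larger maximal response. Compound 2 `CS(=O)(=O)c1ccc(N2CCc3c(OC4CCN(C(=O)OCCF)CC4)ncnc32)c(F)c1` gives 86% and compound 3 `COCCOC(=O)N1CCC(Oc2ncnc3c2CCN3c2ccc(S(C)(=O)=O)cc2F)CC1` gives 86% in this assay; the three numbers sit within the scatter of one another, as the steps of a number 5 percentage points lower from compound 1 to compound 2 (within the scatter), a number 5 percentage points lower from compound 1 to compound 3 (within the scatter) and no change at the digits printed from compound 2 to compound 3 (within the scatter) show. Compound 4 `CC(C)OC(=O)N1CCC(Oc2ncnc3c2CCN3c2ccc([S+]([O-])N(C)C)cc2)CC1` differs from compound 1 by a group of 11 heavy atoms (8 carbon, 1 nitrogen, 1 oxygen, 1 sulfur; one six-membered aromatic ring of carbon only) in place of a group of 11 heavy atoms (7 carbon, 2 oxygen, 1 fluorine, 1 sulfur; one six-membered aromatic ring of carbon only), on a nitrogen on an aromatic ring in a ring. Going by the values given here, none of the measured steps touches this part of the structure; all three concern the substituent on the oxygen next to the carbonyl group, and they were flat. The aryl change in compound 4 is therefore without precedent here, so the expected step of a number 6 percentage points lower from compound 1 to compound 4 (within the scatter) is set at about none, with wide uncertainty. For compound 4 the maximal response is estimated at 85%, range 55% to 105%.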

Compound 4, largest response reached (reported as percent of maximum), in percent of the reference or control that the assay uses: 128%
Compound 4: middle estimate off by 43 percentage points, on the low side; the whole stated range lies below it.
By their numbers in this assay, from the lowest: compounds 2, 3 and 1 (each within the scatter of the next); then compound 4.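

Unlike the flat steps on the oxygen next to a carbonyl group, the change on a nitrogen on an aromatic ring in a ring moves the maximal response in this assay, giving a number 37 percentage points higher from compound 1 to compound 4 (beyond the scatter) when the group of 11 heavy atoms (8 carbon, 1 nitrogen, 1 oxygen, 1 sulfur) replaces 2-fluoro-4-(methylsulfonyl)phenyl. The swap removes the fluorine and alters the sulfur group together, so the step cannot be assigned to either alone. Nothing at hand accounts for the step.

Open, from the compounds shown here alone, is whether a phenyl bearing a nitrile or a carboxylic acid in place of the sulfur group would keep this response. Also open, going by these compounds, is whether the step carries over to the 2-fluoroethyl and 2-methoxyethyl groups.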